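This account rests on a few compounds, and the source may have more. Where it says the series, first, only, none or still open, it means among the compounds named here.

Working notes on the series. Compound 1 `CNC(=O)c1ccc(=O)n(Cc2cc(Br)ccc2F)c1`, compound 2 `CNC(=O)c1cc(C(=O)NC2CCOCC2)cn(Cc2ccccc2)c1=O` and compound 3 `CNC(=O)c1cc(C(=O)NC2CC2)cn(Cc2cccc(OC)c2)c1=O` have been measured in a physicochemical assay for solubility; a higher number here means a more soluble compound, a lower number a less soluble compound. For compound 1 the reading is a limit of the assay, >= 143 ug/mL. For compound 2 the reading is also a limit, >= 174 ug/mL, so compound 2 stands at the edge of what this assay reports and has no number of its own. Compound 3 gives 79 ug/mL. No two measured compounds differ in one place, so no measured step is shown. Compound 4 `CNC(=O)c1cc(C(=O)NCCOC)cn(Cc2ccccc2)c1=O` is not yet measured; it differs from compound 2 in one place: 2-methoxyethyl in place of oxan-4-yl on an amide-type nitrogen. The step of an at least 1.0-fold lower number from compound 2 to compound 4 (0.01 log units; that floor lies within the scatter) is expected to stay within the scatter. For compound 4 the estimate is 170 ug/mL, between 80 ug/mL and 320 ug/mL.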

Compound 4, solubility: >= 164 ug/mL
Compound 4: no number, only a limit; the forecaster's own chance of this, stated with the estimate: 60%; the middle value does not contradict the limit.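

In this assay, among the compounds shown here, compound 2 and compound 4 both give only a limit, so no step between them can be read. The compounds shown leave open whether 2-methoxyethyl in place of oxan-4-yl changes the reading at all.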